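This account rests on a few compounds, and the source may have more. Where it says the series, first, only, none or still open, it means among the compounds named here.

In a functional assay on NB-4 cells (Homo sapiens) for inhibition, read by XTT assay, with a stated time of 48 h (a higher number here means a weaker inhibitor, a lower number a stronger inhibitor), compound 2 `COc1ccc(C(=O)/C(=C/c2ccc([N+](=O)[O-])cc2)CC(C)C)cc1` gives 600 nM. Compound 1 `COc1ccc(C(=O)/C(=C/c2ccc([N+](=O)[O-])cc2)CCOC(C)=O)cc1` reaches only the limit of > 100000 nM in this assay. Going by the values given here, the single measured step, an at least 160-fold lower number from compound 1 to compound 2 (2.22 log units; beyond the scatter), is the only guide, and its true size is open because one value sits at the limit of > 100000 nM in this assay, at which 1 of the 2 values shown sits. Compound 3 `CCN(CC)C/C(=C\c1ccc([N+](=O)[O-])cc1)C(=O)c1ccc(OC)cc1` carries diethylamino in place of isopropyl on a saturated chain carbon bound to a double-bonded chain carbon. This swap sits at the same place as the measured step, yet that step gives no direction for a diethylamino group, so no change beyond the scatter is expected. Compound 3 is therefore expected at about 450 nM, within 80 nM to 3000 nM. The expected step is a 1.3-fold lower number from compound 2 to compound 3 (0.12 log units; within the scatter).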

Compound 3, half-maximal inhibitory concentration: 1200 nM
Compound 3: the middle estimate sits 2.7-fold (0.43 log units) below what was measured, and the stated range covers the measured number.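

In this assay, diethylamino and isopropyl cannot be told apart at this position: a 2.0-fold higher number from compound 2 to compound 3 (0.30 log units; within the scatter), so this place accepts a larger group that carries a nitrogen. Diethylamino also stands far from acetoxymethyl, with an at least 83-fold lower number from compound 1 to compound 3 (1.92 log units; beyond the scatter), so the weak result of compound 1 goes with acetoxymethyl and not with every replacement of isopropyl. Compound 1 stands at a limit of the assay, so this step gives only a minimum: the limit of > 100000 nM in this assay, at which 1 of the 3 values shown sits.

Going by these compounds, whether a primary amine, a carboxylic acid or a longer chain would be accepted at this place remains open.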